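The compounds below may be only part of what the source reports. "The series", "measured", "known", "first", "only" and "open" are said of these compounds alone.

Of the compounds shown here, three have been tested so far in a functional assay on Hep 3B2 cells (Homo sapiens) for inhibition, read by MTT assay; a lower number here means a stronger inhibitor, a higher number a weaker inhibitor: compound 1 `C[C@@H]1C(=O)O[C@H]2CC3=C[C@@H](C[C@@](C)(O)/C=C/[C@@H]21)OC3=O`, compound 2 `C=C1C(=O)O[C@H]2CC3=C[C@@H](C[C@@](C)(O)/C=C/[C@H]12)OC3=O` and compound 3 `C=C(C(=O)OC)[C@H]1/C=C/[C@](C)(O)C[C@@H]2C=C(C[C@@H]1OC(=O)/C(C)=C\C)C(=O)O2`. Compound 1 reads > 20000 nM, which is a limit of the assay and not a number. Compound 2 reads > 20000 nM, again a limit. Compound 3 reads > 20000 nM, also a limit, so it cannot be given an exact place on the scale. Within the data shown here, the whole series so far comes down to one observation: the limit of > 20000 nM in this assay, at which 3 of the 3 values shown sit.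

The next compound is compound 4 `C=C(C)C(=O)O[C@H]1CC2=C[C@@H](C[C@@](C)(O)/C=C/[C@@H]1C(=C)C(=O)OC)OC2=O`, which keeps the core of compound 3 and differs only in its ester group. There, 1-methylethenyl stands in place of 1-methylprop-1-en-1-yl on a carbonyl carbon: 1-methylethenyl in place of 1-methylprop-1-en-1-yl on a carbonyl carbon. Among the measured compounds shown here, no pair of measured compounds differs in one place, so no measured step offers a guide to the size of this one. The expectation rests on compound 3, whose reading of > 20000 nM is a limit, and on the change being confined to this single group. The estimated step of a number no higher from compound 3 to compound 4 (the limit leaves the size open) is expected to stay within the usual scatter of this assay, with no clear direction. For compound 4 the expected value is 20000 nM, with an estimated range from 8000 nM to 40000 nM.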

Compound 4, half-maximal inhibitory concentration: > 20000 nM
Compound 4 gave a limit, no number; the forecaster's own chance of this, stated with the estimate: 70%; the middle value sits exactly at the limit.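

Among these compounds, compound 3 and compound 4 are both reported only as limits in this assay, so no step between them can be read. The series still comes down to one observation: the limit of > 20000 nM in this assay, at which 4 of the 4 values shown sit. The compounds shown leave open what exact value any of them has, and whether 1-methylethenyl in place of 1-methylprop-1-en-1-yl changes it.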